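Amide series on the shared core: dichlorophenyl step

The compounds below may be only part of what the source reports. "The series", "measured", "known", "first", "only" and "open" are said of these compounds alone.

Measured so far:
compound 1, `O=C(Nc1cc(-c2ccccc2)nn1-c1ccccc1)c1cccc(C(F)(F)F)c1` — 1650 nM
compound 2, `O=C(Nc1cc(-c2ccccc2)nn1-c1ccccc1)c1ccc(C(F)(F)F)cc1` — 990 nM

In an assay on HEK293 cells for displacement of a labelled ligand from metabotropic glutamate receptor 5 (Rattus norvegicus) (on this read-out higher numbers stand for weaker inhibition and lower numbers for stronger inhibition), compound 1 gives 1650 nM, the higher of the two numbers measured; in this assay compound 2 gives 990 nM. Among the compounds with values here, the only measured step is a 1.7-fold lower number from compound 1 to compound 2 (0.22 log units; within the scatter), so the two values are within the scatter of each other and no order can be read from them.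

Compound 3, `O=C(Nc1cc(-c2ccccc2)nn1-c1ccccc1)c1ccc(Cl)c(Cl)c1`, is not yet measured in this assay. It differs from compound 1 by 3,4-dichlorophenyl in place of 3-(trifluoromethyl)phenyl on a carbonyl carbon. Within the data shown here, no measured step changes the aryl group itself; the sole step available, from compound 1 to compound 2, moves the trifluoromethyl group and stays within the scatter. That step bears on the new change only weakly. On this basis compound 3 is expected to lie close to compound 1, with a step of about a 1.4-fold lower number from compound 1 to compound 3 (0.14 log units; within the scatter) expected, not clearly beyond the scatter. The estimate for compound 3 in this assay is 1200 nM, with a range from 400 nM to 4000 nM.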

Compound 3, inhibition constant: 160 nM
Estimate against measurement, compound 3: 7.5-fold (0.88 log units) above; measured number below the stated range.
By their numbers in this assay, from the lowest: compound 3; then compounds 2 and 1 (each within the scatter of the next).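

In this assay, the aryl group on the carbonyl carbon turns out to be a place where the number can shift clearly: 3,4-dichlorophenyl gives a 10-fold lower number from compound 1 to compound 3 (1.01 log units; beyond the scatter) and also a 6.2-fold lower number from compound 2 to compound 3 (0.79 log units; beyond the scatter). The two trifluoromethyl compounds, within the scatter of each other, showed no such shift, whereas both new steps lie beyond the scatter and leave compound 3 with the lowest number of the three. No data at hand explain why this aryl group separates from the other two.

Still open, from the compounds shown here alone, is whether both chlorines are needed, or whether a single chlorine, a methoxy group or a nitrile on this phenyl ring would read the same. Going by these compounds, how the step carries over to other amides on the shared core also remains unknown.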